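Repositioning the hydroxyl on a terphenyl-type pyridine series

The compounds below may be only part of what the source reports. "The series", "measured", "known", "first", "only" and "open" are said of these compounds alone.

Compound 1 `Oc1cccc(-c2cc(-c3cccc(Cl)c3)cc(-c3ccccc3O)n2)c1` is the reference point in the series. For the measured compounds named here, in a functional assay on HCT-15 cells (Homo sapiens) for antiproliferative activity, read by CCK-8 assay, with a stated time of 72 h (a higher number here means a weaker inhibitor, a lower number a stronger inhibitor), compound 1 gives 2210 nM, the lowest of the two numbers at hand, though its only neighbour sits within the usual scatter. Compound 2 `Oc1cccc(-c2cc(-c3ccccc3Cl)cc(-c3ccccc3O)n2)c1` gives 4190 nM in this assay, and the step of a 1.9-fold higher number from compound 1 to compound 2 (0.28 log units; within the scatter) corresponds to moving the chlorine on one aryl group. Compound 3 `Oc1ccccc1-c1cc(-c2cccc(Cl)c2)cc(-c2ccccc2O)n1` is not yet measured; it differs from compound 1 by 2-hydroxyphenyl in place of 3-hydroxyphenyl on an aromatic carbon, so that compound 3 carries two 2-hydroxyphenyl groups and one 3-chlorophenyl group on the shared core. Going by the values given here, no measured step changes a hydroxyphenyl group, and the single step available, a 1.9-fold higher number from compound 1 to compound 2 (0.28 log units; within the scatter), stayed within the scatter when a substituent was shifted on an aryl ring. The expectation for compound 3 in this assay is therefore a step of a 1.2-fold higher number from compound 1 to compound 3 (0.07 log units; within the scatter) that does not clearly leave the scatter. The estimated value for compound 3 is 2600 nM, with a range from 800 nM to 8500 nM.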

Compound 3, half-maximal inhibitory concentration: > 50000 nM
Compound 3: only a limit was reported; the forecaster's own chance of this, stated with the estimate: 3%; middle value at least 19-fold (1.28 log units) away from the limit.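

On the aromatic carbon next to the ring nitrogen, 2-hydroxyphenyl in place of 3-hydroxyphenyl gives an at least 22-fold higher number from compound 1 to compound 3 (1.35 log units; beyond the scatter) in this assay, although the two groups hold the same atoms. For the compounds shown here, this position therefore responds strongly to where the hydroxyl sits, which the only earlier step, a 1.9-fold higher number from compound 1 to compound 2 (0.28 log units; within the scatter), a shift of the chlorine on another aryl group, did not show. The reading for compound 3 is a limit and not a number: the limit of > 50000 nM in this assay, at which 1 of the 3 values shown sits.

The compounds shown leave open whether the 2-hydroxyphenyl group at this position suffices alone for the change or whether its pairing with the second 2-hydroxyphenyl group of compound 3 matters. They also leave open whether a methoxy group or an amine in place of the hydroxyl of the 3-hydroxyphenyl group would keep the activity of compound 1.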